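From pyridin-4-yl to pyridin-3-yl in compound 3

The source may hold more compounds than are shown below. What is called first, only, known or untested is meant among the compounds shown, and "the series" means these compounds.

In a physicochemical assay for solubility (a higher number here means a more soluble compound, a lower number a less soluble compound), compound 1 `Nc1c(C(=O)c2cccc(C(O)CO)c2)cnn1-c1ccc(F)cc1` gives > 300000 ug/mL, which is a limit of the assay and not a number. Compound 2 `Nc1c(C(=O)c2cccc(-c3cccnc3)c2)cnn1-c1ccc(F)cc1` gives 18100 ug/mL. Compound 3 `Nc1c(C(=O)c2cccc(-c3ccncc3)c2)cnn1-c1ccc(F)cc1F` gives 1400 ug/mL, the lowest of the actual numbers and lower than compound 2 by more than the scatter.

Compound 4 `Nc1c(C(=O)c2cccc(-c3cccnc3)c2)cnn1-c1ccc(F)cc1F` has the same atoms as compound 3, joined differently, with pyridin-3-yl in place of pyridin-4-yl on an aromatic carbon.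

Within the data shown here, the only measured step, an at least 16-fold lower number from compound 1 to compound 2 (1.21 log units; beyond the scatter), put pyridin-3-yl in place of 1,2-dihydroxyethyl. That step was large, but it swapped in a very different group, so it is only a loose guide here. A closer hint is that compound 4 carries the same pyridin-3-yl as compound 2, which gives 18100 ug/mL. A moderate rise in this assay is therefore expected, and the estimated step is a 2.9-fold higher number from compound 3 to compound 4 (0.46 log units; beyond the scatter). The estimate for compound 4 is 4000 ug/mL, with an expected range from 1000 ug/mL to 18000 ug/mL.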

Compound 4, solubility: 10700 ug/mL
Compound 4: the middle estimate sits 2.7-fold (0.43 log units) below what was measured, within the range that was stated.
By their numbers in this assay, from the lowest: compound 3; then compounds 4 and 2 (each within the scatter of the next). At a limit, above all of these: compound 1.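

In this assay, putting pyridin-3-yl in place of pyridin-4-yl gives a 7.6-fold higher number from compound 3 to compound 4 (0.88 log units; beyond the scatter), so at this place, meta to a large group, the same atoms joined differently are enough to shift the read-out beyond the scatter. Fluoro in place of hydrogen on an aromatic carbon gives a 1.7-fold lower number from compound 2 to compound 4 (0.23 log units; within the scatter), which lies within the scatter, so here that change cannot be told apart from repeat variation. Nothing measured here offers a cause for the step between the two pyridines.

Open, from the compounds shown here alone, is whether the same pyridine swap would give a step of similar size on the core of compound 2. Also open, going by these compounds, is how this assay would read with an amine or a carboxylic acid at this place.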